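The source may report more compounds than this note shows. Statements on the series, on what has been measured and on what is new or still open speak of the compounds shown alone.

Compound 1 (`CCCCc1cc2cn(COCCO)c(=O)nc2o1`) is the starting point here, and its standing on the numbers is only partly defined. In a functional assay on HEL cells (Homo sapiens) (a higher number here means that more compound is tolerated, a lower number that less compound is tolerated), compound 1 gives > 200000 nM, which is a limit of the assay and not a number. Within the data shown here, compound 2 (`CCCCCCC#Cc1cc2cn(COCCO)c(=O)nc2o1`), the only other compound measured, gives > 50000 nM in this assay, and this too is a limit. Among the measured compounds shown here, the two results therefore offer no numerical value and no measured step from which to judge a structural change.

Compound 3 (`CCCCCCCCCCCc1cc2cn(COCCO)c(=O)nc2o1`) keeps the core of compound 1 and differs from it in one place: heptyl in place of hydrogen on a saturated chain carbon, four bonds along the chain from an aromatic carbon. For the measured compounds named here, with no measured step to serve as a guide, the expectation for this change is tentative. Compound 3 is expected to be somewhat less well tolerated in this assay, although its result may again be reported only as a limit. The estimated change is an at least 3.3-fold lower number from compound 1 to compound 3 (0.52 log units; beyond the scatter), in the direction of less compound tolerated and beyond the usual scatter. For compound 3 the estimated value is 60000 nM, with an expected range from 15000 nM to 200000 nM.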

Compound 3, half-maximal cytotoxic concentration: 132000 nM
Beside the measured number, compound 3's estimate is 2.2-fold (0.34 log units) below it; the range from low to high includes it.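

Among these compounds, with compound 3, this assay gives for the first time a result that is a number and not a limit, so heptyl in place of hydrogen at this place on the chain now has a measured value to stand on. The step reads an at least 1.5-fold lower number from compound 1 to compound 3 (0.18 log units; that floor lies within the scatter); it points to a lower number, but its floor gives no proof of a change beyond the scatter, and the true size of the step could be larger. That size stays unbounded on one side, as the comparison starts from a limit and not from a number: the limit of > 200000 nM in this assay, at which 1 of the 3 values shown sits.

The compounds shown leave open how far the value of compound 1 lies from that of compound 3, and so whether this change matters at all in the assay. They also leave open whether a longer chain, an amine or a carboxylic acid in place of heptyl on this saturated chain carbon would move the number further, or would again return only a limit.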